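From 4,4-difluorocyclohexyl to 2-(thiophen-2-yl)ethenyl on a carbonyl carbon

The source may report more compounds than this note shows. Statements on the series, on what has been measured and on what is new or still open speak of the compounds shown alone.

Values so far in a functional assay on A549 cells (Homo sapiens) for cytotoxicity, read by MTT assay, with a stated time of 48 h; on this read-out higher numbers stand for weaker inhibition and lower numbers for stronger inhibition
compound 1 `C=C1C(=O)O[C@H]2CC3=C[C@H](C/C(C)=C/[C@@H](OC(=O)/C=C/c4ccc(C(F)(F)F)cc4)[C@H]12)OC3=O` gives 5900 nM
compound 2 `C=C1C(=O)O[C@H]2CC3=C[C@H](C/C(C)=C/[C@@H](OC(=O)CC4CCCCC4)[C@H]12)OC3=O` gives 6900 nM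
compound 3 `C=C1C(=O)O[C@H]2CC3=C[C@H](C/C(C)=C/[C@@H](OC(=O)C4CCC(F)(F)CC4)[C@H]12)OC3=O` gives 6400 nM

Compound 3 stands within the scatter of both compound 1 and compound 2, so these three values cannot be ranked. Compound 4 `C=C1C(=O)O[C@H]2CC3=C[C@H](C/C(C)=C/[C@@H](OC(=O)/C=C/c4cccs4)[C@H]12)OC3=O` differs from it by one change, 2-(thiophen-2-yl)ethenyl in place of 4,4-difluorocyclohexyl on a carbonyl carbon and so carries 2-(thiophen-2-yl)ethenyl in place of 4,4-difluorocyclohexyl on a carbonyl carbon. For the measured compounds named here, the only measured step at this place is a 1.1-fold lower number from compound 2 to compound 3 (0.03 log units; within the scatter) and it offers no sign of a shift. Compound 1, which also has an aromatic ring on an ethenyl group, gives 5900 nM and stays level with the others. No step beyond the scatter is therefore expected in this assay and the estimated change is a 1.1-fold lower number from compound 3 to compound 4 (0.03 log units; within the scatter) on this evidence. Compound 4 is expected at 6000 nM within an estimated range of 3000 nM to 12000 nM for now.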

Compound 4, half-maximal inhibitory concentration: 4300 nM
For compound 4 the middle estimate is 1.4-fold (0.14 log units) above the measured one; the range from low to high includes it.
By their numbers in this assay, from the lowest: compounds 4, 1, 3 and 2 (each within the scatter of the next).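

Placing 2-(thiophen-2-yl)ethenyl on the carbonyl carbon in this assay gives a 1.5-fold lower number from compound 3 to compound 4 (0.17 log units; within the scatter) and a 1.6-fold lower number from compound 2 to compound 4 (0.21 log units; within the scatter), while thiophen-2-yl in place of 4-(trifluoromethyl)phenyl gives a 1.4-fold lower number from compound 1 to compound 4 (0.14 log units; within the scatter). A five-membered aromatic ring with a sulfur atom thus reads level with the non-aromatic rings and the 4-(trifluoromethyl)phenyl group, so this position has not yet separated any of the four groups. Nothing available explains these values. The compounds shown leave open whether an amine or a carboxylic acid on this carbonyl carbon would give a step beyond the scatter.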